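The compounds below may be only part of what the source reports. "The series", "measured", "known", "first", "only" and "open" are said of these compounds alone.

In an ADME assay on HEK-293T cells (Homo sapiens) for inhibition, read by luminescence, with a stated time of 72 h, tested at 5 uM (a lower number here means less inhibition of growth, a higher number more inhibition of growth at the concentration tested), compound 3 (`C=CS(=O)(=O)NC/C=C/c1cc(OC)cc(O)c1C(=O)OCC(C)c1ccccc1`) gives 22.5%, second of the three numbers: within the scatter of compound 1 (`C=CS(=O)(=O)NC/C=C/c1cc(OC)cc(O)c1C(=O)OCC1CCCCC1`) at 31.2%, and clearly over compound 2 (`C=CS(=O)(=O)NC/C=C/c1cc(OC)cc(O)c1C(=O)OCc1ccc(Br)cc1`) at 0%. Compound 4 (`COc1cc(O)c(C(=O)OCC(C)c2ccccc2)c(/C=C/CN2C(=O)C=CC2=O)c1`) carries one change: a group of 7 heavy atoms (4 carbon, 1 nitrogen, 2 oxygen; one five-membered non-aromatic ring with 1 hetero atom) in place of a group of 6 heavy atoms (2 carbon, 1 nitrogen, 2 oxygen, 1 sulfur; no ring), on a saturated chain carbon bound to a double-bonded chain carbon. All measured steps replace the group on a saturated chain carbon bound to an oxygen next to a carbonyl group: a number 8.7 percentage points lower from compound 1 to compound 3 (within the scatter), a number 31.2 percentage points lower from compound 1 to compound 2 (beyond the scatter) and a number 22.5 percentage points higher from compound 2 to compound 3 (beyond the scatter). None touches the (vinylsulfonyl)amino group, so they show only how far this assay moves within this series. No step beyond the scatter is expected, and the estimated change is a number 7.5 percentage points higher from compound 3 to compound 4 (within the scatter). For compound 4 the estimate is 30%, with an expected range of 5% to 65%.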

Compound 4, percent growth inhibition at one concentration: 0%
The estimate for compound 4 lay 30 percentage points above the measured number; the measured number lies below the stated range.
By their numbers in this assay, from the lowest: compounds 2 and 4 (each within the scatter of the next); then compounds 3 and 1 (each within the scatter of the next).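

In this assay the group on a saturated chain carbon bound to a double-bonded chain carbon turns out to matter: the five-membered ring group in place of (vinylsulfonyl)amino gives a number 22.5 percentage points lower from compound 3 to compound 4 (beyond the scatter) in this single pair. The earlier steps shown here all lay at the other place, on a saturated chain carbon bound to an oxygen next to a carbonyl group. Nothing available explains this drop.
As far as these compounds go, whether an amine or a carboxylic acid at this place would restore growth inhibition remains open. Also open, from the compounds shown here alone, is whether the same exchange behaves alike with the cyclohexyl group of compound 1.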